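Aryl swap on the lactam nitrogen of the oxadiazole series

A few compounds are considered here, and "the series" means these few. Any claim that something is new, unique, unknown or untested is made for them only; others in the source may bear on it.

Compound 1 `O=C1CC(c2nc(-c3cccc(Cl)c3)no2)CN1c1ccccc1Cl` and compound 2 `Cc1ccc(N2CC(c3nc(-c4cccc(Cl)c4)no3)CC2=O)cc1` share one core and differ only in the aryl group on the amide-type nitrogen of the five-membered ring. In an in vitro functional assay on HEK293-A cells for negative allosteric modulation of metabotropic glutamate receptor 5 (Homo sapiens), read by FLIPR and calcium flux (on this read-out lower numbers stand for stronger inhibition and higher numbers for weaker inhibition), compound 1 gives 680 nM. In this assay compound 2 gives > 10000 nM, which is a limit of the assay and not a number, so compound 2 stands at the limit of > 10000 nM in this assay, at which 1 of the 2 values shown sits, and its exact position within the two values is not known. The measured step of an at least 14-fold higher number from compound 1 to compound 2 (1.16 log units; beyond the scatter) is the only one bearing on the next change. Compound 3 `Cc1ccccc1N1CC(c2nc(-c3cccc(Cl)c3)no2)CC1=O` is not yet measured; it differs from compound 2 by 2-methylphenyl in place of 4-methylphenyl on an amide-type nitrogen in a ring. The 2-methylphenyl of compound 3 resembles the 2-chlorophenyl of compound 1 more closely than the 4-methylphenyl of compound 2 does, so in this assay a step back toward lower numbers is expected, of the order of an at least 5.0-fold lower number from compound 2 to compound 3 (0.69 log units; beyond the scatter), though only a limit anchors its start. Compound 3 is therefore estimated at 2000 nM, within 500 nM to 8000 nM, with a fair chance that a limit is reported again.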

Compound 3, half-maximal inhibitory concentration: 370 nM
Compound 3: the middle estimate sits 5.4-fold (0.73 log units) above what was measured; the whole stated range lies above it.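

In this assay, 2-methylphenyl in place of 4-methylphenyl on the amide-type nitrogen gives an at least 27-fold lower number from compound 2 to compound 3 (1.43 log units; beyond the scatter), so with the same atoms joined differently, where the methyl sits on this aryl group separates the two compounds, a distinction the earlier pair could not make, as it changed both the group and its place at once. The value of compound 2 is a limit of the assay and not a number, so this step has only a bound for its size: the limit of > 10000 nM in this assay, at which 1 of the 3 values shown sits. Methyl in place of chloro on the aromatic carbon gives a 1.8-fold lower number from compound 1 to compound 3 (0.26 log units; within the scatter), which lies within the scatter, so 2-chlorophenyl and 2-methylphenyl cannot be told apart on this read-out.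

The compounds shown leave open how 3-methylphenyl or an unsubstituted phenyl would read on the same nitrogen, and whether 4-chlorophenyl would follow 4-methylphenyl. They also leave open whether a larger or more heteroatom-bearing group in the same place, such as 2-methoxyphenyl or 2-(trifluoromethyl)phenyl, would keep the level seen with 2-chlorophenyl and 2-methylphenyl.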